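This account rests on a few compounds, and the source may have more. Where it says the series, first, only, none or still open, it means among the compounds named here.

Working notes on the series.

Going by the values given here, compound 1, `COc1ccc(-c2cc(/C=C/C(=O)c3ccc(N)cc3)[nH]n2)cc1`, and compound 2, `COc1cc(-c2cc(/C=C/C(=O)c3ccc(Cl)c(Cl)c3)[nH]n2)cc(OC)c1OC`, are the two measured members. In a functional assay on A549 cells (Homo sapiens) for cytotoxicity, read by sulforhodamine B assay, with a stated time of 48 h, tested at 10 uM (a higher number here means a weaker effect of the compound at the concentration tested, a lower number a stronger effect), compound 1 gives 1%, while compound 2 gives 68%. Among the compounds with values here, on these two numbers compound 2 stands highest, and its gap to compound 1, the only neighbour, lies beyond the scatter, so compound 2 is the weaker of the two at the concentration tested. Within the data shown here, the two compounds differ in more than one place, so no single step between them can be separated out.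

Compound 3, `COc1ccc(C(=O)/C=C/c2cc(-c3cc(OC)c(OC)c(OC)c3)n[nH]2)cc1`, is not yet measured in this assay. It differs from compound 2 in one place: 4-methoxyphenyl in place of 3,4-dichlorophenyl on a carbonyl carbon. The rest of the structure is unchanged.

Among the measured compounds shown here, no step between measured compounds is available for this change, so the expectation for compound 3 rests only on where compound 2 stands. A step from compound 2 toward a lower number is expected, a number 23 percentage points lower from compound 2 to compound 3 (beyond the scatter), though its size is uncertain and a result within the scatter of compound 2 cannot be ruled out. The estimate for compound 3 in this assay is 45%, expected to fall between 10% and 80%.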

Compound 3, a percentage reported as activity, at one concentration (the size of the read-out at that concentration, not a potency): -15%
The estimate for compound 3 lay 60 percentage points above the measured number; measured number outside the range, below it.
By their numbers in this assay, from the lowest: compound 3; then compound 1; then compound 2.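

With the rest of the structure unchanged, 4-methoxyphenyl in place of 3,4-dichlorophenyl on a carbonyl carbon gives a number 83 percentage points lower from compound 2 to compound 3 (beyond the scatter) in this assay. Going by these compounds alone, this is the only step that isolates a single place, and it shows that this position alone can shift the read-out strongly at the concentration tested, which the pair of compound 1 and compound 2, differing in more than one place, could not show. Of the two groups compared here, 4-methoxyphenyl carries the stronger effect, with compound 3 at -15%, and nothing at hand explains the step.

Within the data shown here, with only two groups compared at this position, it stays open whether the step follows from the arrival of the methoxy group, the departure of the two chlorine atoms, or both, and how a single chlorine, a hydroxyl group, an amine or a longer alkoxy chain in the same place would read. Also open, going by these compounds, is whether the same change gives a step of similar size on the core of compound 1, where the rest of the structure differs.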